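The source may report more compounds than this note shows. Statements on the series, on what has been measured and on what is new or still open speak of the compounds shown alone.

Working notes on the series. In a functional assay on RS4-11 cells (Homo sapiens) for inhibition, read by CCK-8 assay, with a stated time of 48 h, tested at 20 uM (a lower number here means less inhibition of growth, a higher number more inhibition of growth at the concentration tested), compound 1 (`COc1ccc(S(=O)(=O)Oc2ccccc2/C=C(\C#N)C(=O)Nc2nnc(-c3cccs3)s2)cc1`) gives 76% and compound 2 (`Cc1ccc(S(=O)(=O)Oc2ccccc2/C=C(\C#N)C(=O)Nc2nnc(Cc3ccccc3)s2)cc1`) gives 69% at the single tested concentration. Among the compounds with values here, these two values lie within the scatter of each other, so the numbers do not separate the compounds, and compound 2 stands level with the only other measured compound.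

The next compound is compound 3 (`COc1ccc(S(=O)(=O)Oc2ccccc2/C=C(\C#N)C(=O)Nc2nnc(Cc3ccccc3)s2)cc1`). It carries methoxy in place of methyl on an aromatic carbon, para to a large group (methoxy in place of methyl on an aromatic carbon), so that 4-methylphenyl becomes 4-methoxyphenyl. Within the data shown here, no measured pair differs in one place, so this change has no direct precedent here.

The expectation therefore starts from compound 2 at 69% and assumes that the swap leaves growth inhibition largely where it is. The estimated a number 3 percentage points higher from compound 2 to compound 3 (within the scatter) stays within the scatter, and no change beyond the scatter is expected in either direction in this assay on this evidence. For compound 3 the estimated value is 72% with an expected range from 60% to 84% in this assay.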

Compound 3, percent growth inhibition at one concentration: 78%
Estimate against measurement, compound 3: 6 percentage points below, within the range that was stated.
By their numbers in this assay, from the lowest: compounds 2, 1 and 3 (each within the scatter of the next).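

In this assay, the swap of 4-methylphenyl for 4-methoxyphenyl, on an aromatic carbon para to a large group, can now be read directly with the benzyl group held constant: the step is a number 9 percentage points higher from compound 2 to compound 3 (within the scatter), so at this concentration methoxy and methyl on this ring are not separated. The series also gains a second one-place comparison at the other end of the molecule, where benzyl stands in place of thiophen-2-yl with the 4-methoxyphenyl group held constant; this step, a number 2 percentage points higher from compound 1 to compound 3 (within the scatter), likewise leaves the two groups unseparated, so neither of the two changes shows any effect on growth inhibition that rises above the usual scatter. No separate data accompany these numbers that could bear on how either group acts in the cells.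

As far as these compounds go, whether an amine or a carboxylic acid on the same aromatic carbon, or a longer chain in place of benzyl, would move growth inhibition beyond the scatter remains open. A reading at a single concentration also leaves open whether these compounds would separate across a full concentration range.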